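A few compounds are considered here, and "the series" means these few. Any claim that something is new, unique, unknown or untested is made for them only; others in the source may bear on it.

Going by the values given here, compound 1 `COc1ccc(-c2cc(C)c(Nc3ccnc(Nc4ccc(C#N)cc4)n3)c(C)c2)cc1` gives 2890 nM in an ADME assay on MT4 cells (Homo sapiens) for cytotoxicity, read by MTT assay, with a stated time of 4 days (on this read-out lower numbers stand for higher toxicity in this test and higher numbers for lower toxicity in this test), the lowest of the two numbers known here. Its nearest neighbour is compound 2 `Cc1cc(-c2cccc(C(F)(F)F)c2)cc(C)c1Nc1ccnc(Nc2ccc(C#N)cc2)n1`, which gives 4030 nM in this assay; the step of a 1.4-fold higher number from compound 1 to compound 2 (0.14 log units; within the scatter) stays within the scatter. Compound 3 `Cc1cc(-c2ccccc2)cc(C)c1Nc1ccnc(Nc2ccc(C#N)cc2)n1` differs from compound 1 by hydrogen in place of methoxy on an aromatic carbon. Among the compounds with values here, the only measured step that bears on it, a 1.4-fold higher number from compound 1 to compound 2 (0.14 log units; within the scatter), exchanged a group at the same place and stayed within the scatter, so compound 3 is expected to show a step of a 1.1-fold higher number from compound 1 to compound 3 (0.06 log units; within the scatter) that is within the scatter. Compound 3 is therefore estimated at 3300 nM in this assay, with a range of 1500 nM to 7500 nM.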

Compound 3, half-maximal cytotoxic concentration: 4170 nM
Compound 3: the middle estimate sits 1.3-fold (0.10 log units) below what was measured; low and high end bracket the measured number.
By their numbers in this assay, from the lowest: compounds 1, 2 and 3 (each within the scatter of the next).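

With hydrogen on this aromatic carbon, compound 3 adds the unsubstituted phenyl to the two substituted rings, and in this assay both new steps, a 1.4-fold higher number from compound 1 to compound 3 (0.16 log units; within the scatter) and a 1.0-fold higher number from compound 2 to compound 3 (0.01 log units; within the scatter), stay within the scatter. Across these three compounds, neither methoxy nor trifluoromethyl on this ring separates from hydrogen in this test. Nothing available here explains this result. Going by these compounds, it remains open whether an amine or a carboxylic acid on this ring would also stay within the scatter of compound 3.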